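A few compounds are considered here, and "the series" means these few. Any claim that something is new, unique, unknown or untested is made for them only; others in the source may bear on it.

Compound 2 `C=CCOc1c(C)c(C)c2c(c1C)CCC(C)(COc1ccc(/C=C3\SC(=O)NC3=O)cc1C)O2` and compound 1 `CC(C)=CCOc1c(C)c(C)c2c(c1C)CCC(C)(COc1ccc(/C=C3\SC(=O)NC3=O)cc1C)O2` share one core and differ in a single place, namely (2-methylprop-1-en-1-yl in place of vinyl on a saturated chain carbon bound to an oxygen on an aromatic ring). In a functional assay on MCF7 cells (Homo sapiens), tested at 2.5 uM (a higher number here means a weaker effect of the compound at the concentration tested, a lower number a stronger effect), compound 2 gives 84%, while compound 1 gives 89%, so that the step reads a number 5 percentage points higher from compound 2 to compound 1 (within the scatter). Compound 3 `C=CCOc1c(C)c(C)c2c(c1C)CCC(C)(COc1ccc(/C=C3\SC(=O)NC3=O)cc1OCC)O2` carries a core that differs from the core of compound 2 by ethoxy in place of methyl on an aromatic carbon. In this assay compound 3 gives 107%, which stands as the highest of the three numbers and follows from the step of a number 23 percentage points higher from compound 2 to compound 3 (beyond the scatter). For the measured compounds named here, compound 4 `CCOc1cc(/C=C2\SC(=O)NC2=O)ccc1OCC1(C)CCc2c(C)c(OCC=C(C)C)c(C)c(C)c2O1` has not been measured yet; it differs from compound 3 by 2-methylprop-1-en-1-yl in place of vinyl on a saturated chain carbon bound to an oxygen on an aromatic ring, the same change as the one from compound 2 to compound 1, made at the same place. Since that change produced only a number 5 percentage points higher from compound 2 to compound 1 (within the scatter) on the other core, compound 4 is expected to show a step of a number 3 percentage points higher from compound 3 to compound 4 (within the scatter), a number of similar size. On that basis compound 4 is estimated at 110% in this assay, with an expected range from 95% to 125%.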

Compound 4, a percentage reported as activity, at one concentration (the size of the read-out at that concentration, not a potency): 107%
Compound 4: middle estimate off by 3 percentage points, on the high side; the measured number falls inside the stated range.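

In this assay, for the compounds shown here, the change from allyloxy to (3-methylbut-2-en-1-yl)oxy on the core bearing ethoxy reads no change at the digits printed from compound 3 to compound 4 (within the scatter), and this agrees with the same change on the core bearing methyl: the same change on two cores in this assay, a number 5 percentage points higher (within the scatter) from compound 2 to compound 1 and no change at the digits printed (within the scatter) from compound 3 to compound 4, 5 percentage points apart, within the scatter of two such steps Ethoxy in place of methyl, with the longer chain on the oxygen, reads a number 18 percentage points higher from compound 1 to compound 4 (beyond the scatter), and this likewise agrees with the earlier step: the same change on two cores in this assay, a number 23 percentage points higher (beyond the scatter) from compound 2 to compound 3 and a number 18 percentage points higher (beyond the scatter) from compound 1 to compound 4, 5 percentage points apart, within the scatter of two such steps Both changes therefore carry from one core to the other within these four compounds, but that rests on only two pairs of steps at one concentration, and it shows neither a potency nor that the same would hold on any other core.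

The compounds shown leave open how a saturated chain such as butyl or a benzyl group would read on that oxygen. They also leave open how an amine or a fluorine would read in place of the ethoxy.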